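The source may report more compounds than this note shows. Statements on the series, on what has been measured and on what is new or still open speak of the compounds shown alone.

Compound 3 `Cc1nc(C(=O)N2CC3(CC3)C[C@H]2CNc2ccc(C(F)(F)F)cn2)c(-c2ccccc2)s1` and compound 2 `Cc1nc(C(=O)N2CC3(CC3)C[C@H]2CNc2cc(C(F)(F)F)ccn2)c(-c2ccccc2)s1` were both tested in a functional assay on CHO cells for antagonist activity at Orexin/Hypocretin receptor type 1 (Homo sapiens), read by FLIPR and calcium flux; on this read-out higher numbers stand for higher potency (the scale is a negative logarithm) and lower numbers for lower potency. Compound 3 gives 8.4, and compound 2 gives 8.2. These two differ in a single place: 4-(trifluoromethyl)pyridin-2-yl in place of 5-(trifluoromethyl)pyridin-2-yl on an amine nitrogen. The reading moves by a number 0.20 log units lower from compound 3 to compound 2 (within the scatter). Compound 1 `Cc1ccc(-c2ncccn2)c(C(=O)N2CC3(CC3)C[C@H]2CNc2ccc(C(F)(F)F)cn2)n1` is built on a different core; how the core of compound 1 differs from that of compound 3 is not broken down here. In this assay compound 1 gives 8.4, level with compound 3 at the digits recorded. Compound 4 `Cc1ccc(-c2ncccn2)c(C(=O)N2CC3(CC3)C[C@H]2CNc2cc(C(F)(F)F)ccn2)n1` has not yet been measured. It stands to compound 1 as compound 2 stands to compound 3: 4-(trifluoromethyl)pyridin-2-yl in place of 5-(trifluoromethyl)pyridin-2-yl on an amine nitrogen. The place of the change, an amine nitrogen whose other neighbour is a saturated chain carbon, is the same in both pairs, so this is the same change carried onto another core. Given a number 0.20 log units lower from compound 3 to compound 2 (within the scatter), the same change is expected to produce a number 0.20 log units lower from compound 1 to compound 4 (within the scatter). On that basis compound 4 is estimated to give 8.2, with a likely range from 7.8 to 8.6.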

Compound 4, negative logarithm of the antagonist equilibrium constant: 6
The estimate for compound 4 lay 2.20 log units above the measured number, outside the stated range (below it).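

In this assay, putting 4-(trifluoromethyl)pyridin-2-yl in place of 5-(trifluoromethyl)pyridin-2-yl on the amine nitrogen gives a number 2.40 log units lower from compound 1 to compound 4 (beyond the scatter), a large loss on the core of compound 1. This change therefore does not carry over at a fixed size between the two cores, and a step measured on one core proved a poor guide to the other: the same change on two cores in this assay, a number 0.20 log units lower (within the scatter) from compound 3 to compound 2 and a number 2.40 log units lower (beyond the scatter) from compound 1 to compound 4, 2.20 log units apart, beyond the scatter of two such steps. This does not show why the cores respond so differently or which part of them matters, and with just one pair on each core it sets no rule for the wider series.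

On these data alone, it remains open whether the large loss belongs to the trifluoromethyl group itself, which a nitrile or a chlorine in its place on the same pyridine ring could test on both cores. Also open, as far as these compounds go, is how the same change would behave on a third core, and so which of the two steps is the more typical.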